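Extending the Ethyl Group of Compound 1 with a Methoxyphenyl Ring

The compounds below may be only part of what the source reports. "The series", "measured", "known", "first", "only" and "open" are said of these compounds alone.

Compound 1 `CCc1nc(N)c2nn(-c3ccccc3)cc2n1` stands highest of the three measured compounds: in an assay on CHO cells for displacement of a labelled ligand from adenosine receptor A3 (Homo sapiens), read by scintillation counting, tested at 1 uM (a higher number here means more inhibition at the concentration tested (going by the name of the read-out), a lower number less inhibition), compound 1 gives 38%, with compound 3 `Nc1nc(/C=C/c2ccccc2)nc2cn(-c3ccccc3)nc12` nearest at 25% and compound 2 `Nc1nc(Cc2ccccc2Cl)nc2cn(-c3ccccc3)nc12` furthest at 22%. Compound 4 `COc1ccc(CCc2nc(N)c3nn(-c4ccccc4)cc3n2)cc1` differs from compound 1 by 4-methoxyphenyl in place of hydrogen on a saturated chain carbon, two bonds along the chain from an aromatic carbon. For the measured compounds named here, two measured steps bear on this change, both starting from compound 1 and both adding an aromatic ring to the two-carbon substituent: a number 16 percentage points lower from compound 1 to compound 2 (beyond the scatter) and a number 13 percentage points lower from compound 1 to compound 3 (beyond the scatter). Each aryl extension lowered inhibition by a modest amount beyond the scatter, so a comparable downward step is expected here. Compound 4 is therefore estimated to give 23% (range 9% to 37%) in this assay, an expected step of a number 15 percentage points lower from compound 1 to compound 4 (beyond the scatter), resting on the lowering seen in compound 2 at 22% and compound 3 at 25%.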

Compound 4, a percentage reported as inhibition, at one concentration (the size of the read-out at that concentration, not a potency): 22%
Compound 4: middle estimate off by 1 percentage points, on the high side; low and high end bracket the measured number.
By their numbers in this assay, from the lowest: compounds 2, 4 and 3 (each within the scatter of the next); then compound 1.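

In this assay the 4-methoxyphenyl group on this saturated chain carbon brings a number 16 percentage points lower from compound 1 to compound 4 (beyond the scatter) and so adds a third aromatic extension of the two-carbon substituent that lowers the number, now with the ring held on a fully saturated link and carrying an oxygen. Compounds 2, 4 and 3 lie within the scatter of one another, so neither the saturated link nor the methoxy-bearing ring sets compound 4 apart from the 2-chlorobenzyl and 2-phenylethenyl compounds. No measured evidence bears on the reason for this lowering.

On these data alone, whether a group without a ring at this chain carbon, such as a hydroxyl, an amine or a carboxylic acid, would hold or raise the number stays open. So does the outcome for a plain phenyl or a longer unbranched carbon chain at this place.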